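The source may hold more compounds than are shown below. What is called first, only, known or untested is meant among the compounds shown, and "the series" means these compounds.

Measured so far: compound 1 `CC(C)[C@@H](O)[C@H](O)C(=O)NS(=O)(=O)OC[C@H]1O[C@@H](n2cnc3c(N)ncnc32)C[C@@H]1O` gives 4720 nM in a functional assay on SNU-638 cells (Homo sapiens) for antiproliferative activity, read by sulforhodamine B assay, with a stated time of 72 h; a higher number here means a weaker inhibitor, a lower number a stronger inhibitor; compound 2 `CO[C@H](C(=O)NS(=O)(=O)OC[C@H]1O[C@@H](n2cnc3c(N)nc(Cl)nc32)[C@H](O)[C@@H]1O)[C@H](OC)C(C)C` reaches only the limit > 20000 nM; compound 3 `CC(C)C[C@H](O)C(=O)NS(=O)(=O)OC[C@H]1O[C@@H](n2cnc3c(=O)[nH]cnc32)[C@H](O)[C@@H]1O` likewise sits at the limit > 20000 nM.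

Compound 2 stands at the upper end of the numbers shown, since its value is a limit rather than a number, and the limit of > 20000 nM in this assay, at which 2 of the 3 values shown sit, holds for it as for compound 3. The unmeasured compound 4 `CC(C)C[C@H](Cl)C(=O)NS(=O)(=O)OC[C@H]1O[C@@H](n2cnc3c(N)nc(Cl)nc32)[C@H](O)[C@@H]1O` differs from compound 2 by a group of 6 heavy atoms (5 carbon, 1 chlorine; no ring) in place of a group of 9 heavy atoms (7 carbon, 2 oxygen; no ring), on a carbonyl carbon. Among the compounds with values here, no measured step shows the effect of such a change, so the direction is open. Compound 4 is expected to give about 15000 nM in this assay, within 3000 nM to 40000 nM, a step of an at least 1.3-fold lower number from compound 2 to compound 4 (0.12 log units; that floor lies within the scatter) that may again end at the limit.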

Compound 4, half-maximal inhibitory concentration: 5500 nM
Estimate against measurement, compound 4: 2.7-fold (0.44 log units) above, and the stated range covers the measured number.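

In this assay, within the data shown here, this is the first readable step on a carbonyl carbon: a group of 6 heavy atoms (5 carbon, 1 chlorine; no ring) in place of a group of 9 heavy atoms (7 carbon, 2 oxygen; no ring) gives an at least 3.6-fold lower number from compound 2 to compound 4 (0.56 log units; beyond the scatter). Going by these compounds, the change can therefore move the compound off the limit, and the true size of the step remains unknown. Compound 2 has a limit and not a number: the limit of > 20000 nM in this assay, at which 2 of the 4 values shown sit.

The compounds shown leave open whether the step follows the chlorine or the loss of the two oxygens. They also leave open how an amine or a carboxylic acid in this group would read.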